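Replacing a trifluoromethylcyclopropyl group: expected stability of compound 4

The source may report more compounds than this note shows. Statements on the series, on what has been measured and on what is new or still open speak of the compounds shown alone.

Measured compounds and their half-lives:
- compound 1, `CC(C)(C)c1ccc(C(=O)NCc2ccc(NS(C)(=O)=O)cc2F)cc1`: 0.483 h
- compound 2, `CC(C)(C)c1ccc(C(=O)NCc2c(Cl)cc(NS(C)(=O)=O)cc2Cl)cc1`: 1.37 h
- compound 3, `CS(=O)(=O)Nc1ccc(CNC(=O)c2ccc(C3(C(F)(F)F)CC3)cc2)c(Cl)c1`: 3.03 h

All three were run in an ADME assay on microsomes from liver (Rattus norvegicus, strain Sprague-Dawley) for metabolic stability, read by HPLC, using NADPH, with stated times of 5 min and 60 min, tested at 10 uM; on this read-out lower numbers stand for a shorter-lived compound and higher numbers for a longer-lived compound. Compound 3 shows the longest half-life of the three numbers; the nearest is compound 2 at 1.37 h, a gap beyond the scatter, and the furthest is compound 1 at 0.483 h, also beyond the scatter.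

Compound 4, `COC(C)(C)c1ccc(C(=O)NCc2ccc(NS(C)(=O)=O)cc2Cl)cc1`, keeps the core of compound 3 and changes only the group on an aromatic carbon of a six-membered aromatic ring of carbon only, para to a large group: 1-methoxy-1-methylethyl in place of 1-(trifluoromethyl)cyclopropyl on an aromatic carbon.

Going by the values given here, no measured pair differs in just this one place, so the step must be estimated. Compounds 1 and 2 carry a tert-butyl group in that position and both sit well below compound 3, which suggests that the trifluoromethylcyclopropyl group goes together with the higher number. A methoxy-bearing group is expected to move the number back down by a moderate amount, beyond the scatter. The expected step is a 3.0-fold lower number from compound 3 to compound 4 (0.48 log units; beyond the scatter), giving an estimated half-life for compound 4 of 1 h, within 0.4 h to 2.5 h.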

Compound 4, half-life: 0.917 h
Beside the measured number, compound 4's estimate is 1.1-fold (0.04 log units) above it; measured number inside the range.
By their numbers in this assay, from the lowest: compounds 1, 4 and 2 (each within the scatter of the next, the first and the last beyond it); then compound 3.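

Going by these compounds alone, this is the first change at this position that can be read on its own. Compound 3 and compound 4 differ only in the group on an aromatic carbon, para to a large group, and in this assay putting 1-methoxy-1-methylethyl in place of 1-(trifluoromethyl)cyclopropyl gives a 3.3-fold lower number from compound 3 to compound 4 (0.52 log units; beyond the scatter), a modest step that lies beyond the usual scatter, so the group at this position alone can shift the half-life measurably. Nothing shown here explains why the number moves.

The step also changes several things at once: the three-membered ring and the fluorines leave while an oxygen enters, and the two compounds cannot show which of these changes accounts for the shorter half-life. Groups that change one feature at a time, such as a plain cyclopropyl, a 1-methylcyclopropyl or a 1-hydroxy-1-methylethyl at the same place, and a tert-butyl on the core of compound 3, would begin to separate the contributions of the ring, the fluorines and the oxygen.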